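This account rests on a few compounds, and the source may have more. Where it says the series, first, only, none or still open, it means among the compounds named here.

Measured compounds and their values:
- compound 1 `COc1cc(C)cc(-c2c(-c3ccnc(-c4ccc(C(C)=O)cc4)c3)cnn2CC#N)c1` gives 91%
- compound 2 `Cc1cc(O)cc(-c2nn(CC#N)cc2-c2ccnc(-c3ccc(Oc4ccccc4)cc3)c2)c1` gives 96%
- compound 3 `COc1cc(C)cc(-c2nn(CC#N)cc2-c2ccnc(-c3ccc(N(C)C)cc3)c2)c1` gives 99%

In a functional assay on NCI/ADR-RES cells (Homo sapiens) for cytotoxicity, read by sulforhodamine B assay, with a stated time of 48 h, tested at 0.01 uM (a higher number here means a weaker effect of the compound at the concentration tested, a lower number a stronger effect), all three measured compounds come out near the top of the scale. Compound 3 stands at the highest of the three numbers, but its nearest neighbour, compound 2, lies within the scatter of compound 3, and so does the furthest, compound 1. On the numbers shown, then, the three cannot be told apart.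

The unmeasured compound 4 `Cc1cc(O)cc(-c2nn(CC#N)cc2-c2ccnc(-c3ccc(N(C)C)cc3)c2)c1` is reached from compound 3 by a single change: hydrogen in place of methyl on an oxygen on an aromatic ring. The hydroxy form already occurs in compound 2, which in this assay gives 96%, a number that does not separate from compound 3. For the measured compounds named here, no step between measured compounds exists to set a size for this change, so no movement beyond the scatter is expected. Compound 4 is therefore estimated to show a step of a number 2 percentage points lower from compound 3 to compound 4 (within the scatter) and a value of 97%, with a range from 88% to 105%.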

Compound 4, a percentage reported as activity, at one concentration (the size of the read-out at that concentration, not a potency): 96%
Compound 4: middle estimate off by 1 percentage points, on the high side, within the range that was stated.
By their numbers in this assay, from the lowest: compounds 1, 2, 4 and 3 (each within the scatter of the next).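

In this assay, the change from methoxy to hydroxy now has a measured size for one pair: a number 3 percentage points lower from compound 3 to compound 4 (within the scatter). With the hydroxy form in place on the 3-hydroxy-5-methylphenyl group, dimethylamino in place of phenoxy on an aromatic carbon also has a measured size: no change at the digits printed from compound 2 to compound 4 (within the scatter). Neither change separates its pair at this concentration, and nothing available accounts for either step.

Still open, from the compounds shown here alone, is whether a larger group on this oxygen, such as ethyl or benzyl, or a carboxylic acid in place of dimethylamino on the aromatic carbon, would move the number beyond the scatter. Going by these compounds, with all four compounds read at a single concentration, it is also open whether either step would keep its size at a higher one.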